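This account rests on a few compounds, and the source may have more. Where it says the series, first, only, none or still open, it means among the compounds named here.

Two compounds share one core and differ only in the group on the carbonyl carbon. Compound 1 `O=C(CCCl)Nc1ccc(S(=O)(=O)Oc2ccccc2I)cc1` carries a 2-chloroethyl there, and in a functional assay on HT-29 cells (Homo sapiens) for antiproliferative activity, read by sulforhodamine B assay, with a stated time of 48 h (a higher number here means a weaker inhibitor, a lower number a stronger inhibitor), compound 1 gives 14000 nM. Compound 2 `CCCNC(=O)Nc1ccc(S(=O)(=O)Oc2ccccc2I)cc1` carries a propylamino instead, and in this assay compound 2 gives 6800 nM. Going by the values given here, the only measured step is a 2.1-fold lower number from compound 1 to compound 2 (0.31 log units; beyond the scatter). Among these two numbers compound 2 stands lowest, with compound 1 as its nearest neighbour, higher by that same step.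

Compound 3 `CCCCCNC(=O)Nc1ccc(S(=O)(=O)Oc2ccccc2I)cc1` has not been measured. It differs from compound 2 by ethyl in place of hydrogen on a saturated chain carbon, three bonds along the chain from an amide-type nitrogen, so the propyl becomes a pentyl. Among the compounds with values here, no measured step changes a chain at that place: the step from compound 1 to compound 2 swapped one kind of group for another on the carbonyl carbon and says nothing about lengthening a chain that is already present. For compound 3 the change in this assay is therefore expected to be none beyond the scatter, estimated as a 1.2-fold lower number from compound 2 to compound 3 (0.09 log units; within the scatter). Compound 3 is expected to give about 5500 nM in this assay, within a range from 2000 nM to 15000 nM.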

Compound 3, half-maximal inhibitory concentration: 6600 nM
Compound 3: middle estimate off by 1.2-fold (0.08 log units), on the low side; the range from low to high includes it.
By their numbers in this assay, from the lowest: compounds 3 and 2 (each within the scatter of the next); then compound 1.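

In this assay, extending the propyl of compound 2 to the pentyl of compound 3 places an ethyl on a saturated chain carbon, three bonds along the chain from an amide-type nitrogen, and gives a 1.0-fold lower number from compound 2 to compound 3 (0.01 log units; within the scatter), so these two chain lengths cannot be told apart in this test. Going by these compounds alone, this is the first reading of a chain extended at this place, since the earlier step exchanged one kind of group for another on the carbonyl carbon, and it shows that the extra ethyl is accepted here with no measurable gain or loss. The exchange of the 2-chloroethyl group also holds up with the longer chain, as a 2.1-fold lower number from compound 1 to compound 3 (0.33 log units; beyond the scatter) is still beyond the usual scatter, but nothing available here accounts for any of these results.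

Going by these compounds, with only propyl and pentyl to compare, it remains open whether a shorter ethyl, a much longer chain such as decyl, or a branched chain such as isopropyl would give a different number. On these data alone, it is equally open what a chain ending in an amine or a carboxylic acid, or a cyclohexyl ring in place of the chain, would do.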